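This account rests on a few compounds, and the source may have more. Where it says the series, first, only, none or still open, it means among the compounds named here.

Measured so far in a physicochemical assay for lipophilicity; a lower number here means a more polar compound, a higher number a more lipophilic compound:
- compound 1 `C[C@H]1CC[C@@H]2[C@@H](OC(=O)[C@]23CC(c2ccc([N+](=O)[O-])cc2)=NO3)[C@]2(C)C(=O)C=C[C@@]12O`: 1.37
- compound 2 `C[C@H]1CC[C@@H]2[C@@H](OC(=O)[C@]23CC(c2ccc(C#N)cc2)N(c2ccccc2)O3)[C@]2(C)C(=O)C=C[C@@]12O`: 2.94
- compound 3 `COc1ccc(C2C[C@@]3(ON2c2ccccc2)C(=O)O[C@@H]2[C@H]3CC[C@H](C)[C@]3(O)C=CC(=O)[C@@]23C)cc1`: 3.25

Compound 3 stands highest of the three numbers in this assay. Compound 2 is its nearest neighbour and compound 1 lies furthest away, with both gaps beyond the scatter.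

The next compound is compound 4 `C[C@H]1CC[C@@H]2[C@@H](OC(=O)[C@]23CC(c2c(F)cccc2F)N(c2ccccc2)O3)[C@]2(C)C(=O)C=C[C@@]12O`. In it, 2,6-difluorophenyl takes the place of 4-methoxyphenyl on a saturated ring carbon (2,6-difluorophenyl in place of 4-methoxyphenyl on a saturated ring carbon). The rest of the structure is unchanged.

Within the data shown here, only one measured step bears on this change: a number 0.31 log units higher from compound 2 to compound 3 (beyond the scatter). There, methoxy takes the place of cyano on an aromatic carbon, and the step is modest. It shows that a change on this aromatic group can move the number by a modest amount, but it involves no fluorine and gives only a rough guide to size. Among the measured compounds shown here, no measured compound carries fluorine, so the direction rests on weak evidence.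

A small upward move, not clearly beyond the scatter, is therefore expected. The expected step is a number 0.10 log units higher from compound 3 to compound 4 (within the scatter). The estimated value for compound 4 is 3.35, with an expected range from 2.9 to 3.8.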

Compound 4, partition coefficient: 3.42
The estimate for compound 4 lay 0.07 log units below the measured number, and the stated range covers the measured number.
By their numbers in this assay, from the lowest: compound 1; then compound 2; then compounds 3 and 4 (each within the scatter of the next).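

In this assay, among these compounds, the first fluorine-bearing aryl group on this saturated ring carbon, next to the ring nitrogen, gives a number 0.17 log units higher from compound 3 to compound 4 (within the scatter) and so cannot be told apart from 4-methoxyphenyl at this position. Set against 4-cyanophenyl, the same group gives a number 0.48 log units higher from compound 2 to compound 4 (beyond the scatter) and thus adds a second step at this carbon that lies beyond the scatter, alongside the one already seen for the methoxy-for-cyano change; among these three aryl groups, only 4-cyanophenyl stands apart, with 2,6-difluorophenyl and 4-methoxyphenyl both on the same side of it. No measurement in hand accounts for either step.

The compounds shown leave open whether the two fluorines both matter to the reading, since a phenyl with a single fluorine is not among them, and whether the place of the substituents on the aromatic ring counts for anything apart from their identity. Also open, on these data alone, is how an aryl group carrying an amine or a carboxylic acid would read in this assay at this carbon, and whether these steps would hold with a group other than phenyl on the ring nitrogen.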